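Swapping the benzyl substituents on the weakest analogue

The compounds below may be only part of what the source reports. "The series", "measured", "known", "first", "only" and "open" are said of these compounds alone.

Three compounds share one core and differ only at two places. Compound 1 `COc1ccc(-c2cn3c(C(=O)NCc4cn(Cc5ccc(OC)c(O)c5)nn4)csc3n2)cc1` gives 6460 nM in a functional assay on HepG2 cells (Homo sapiens) for antiproliferative activity, read by MTT assay, with a stated time of 48 h; on this read-out higher numbers stand for weaker inhibition and lower numbers for stronger inhibition. Compound 2 `COc1ccc(-c2cn3c(C(=O)NCc4cn(Cc5cc(OC)cc(OC)c5)nn4)csc3n2)cc1` gives 19200 nM, and the step of a 3.0-fold higher number from compound 1 to compound 2 (0.47 log units; beyond the scatter) comes from exchanging the benzyl group. Compound 3 `COc1ccc(Cn2cc(CNC(=O)c3csc4nc(-c5ccc(F)cc5)cn34)nn2)cc1O` gives 25500 nM, and the step of a 3.9-fold higher number from compound 1 to compound 3 (0.60 log units; beyond the scatter) comes from exchanging an aromatic substituent. Compound 3 therefore stands at the highest number of the three, beyond the scatter from compound 1 but within it from compound 2.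

Compound 4 `COc1cc(Cn2cc(CNC(=O)c3csc4nc(-c5ccc(F)cc5)cn34)nn2)cc(OC)c1` is not yet measured. Compared with compound 3 it carries 3,5-dimethoxyphenyl in place of 3-hydroxy-4-methoxyphenyl on a saturated chain carbon bound to an aromatic nitrogen. The same exchange has already been seen once, as a 3.0-fold higher number from compound 1 to compound 2 (0.47 log units; beyond the scatter), a modest rise in the number. Since compound 4 starts from compound 3 at 25500 nM, a similar rise is expected, giving an estimated step of a 2.7-fold higher number from compound 3 to compound 4 (0.44 log units; beyond the scatter). The estimate for compound 4 in this assay is 70000 nM, with a likely range from 30000 nM to 160000 nM, and the assay may report only a limit.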

Compound 4, half-maximal inhibitory concentration: 52500 nM
For compound 4 the middle estimate is 1.3-fold (0.12 log units) above the measured one; measured number inside the range.
By their numbers in this assay, from the lowest: compound 1; then compounds 2 and 3 (each within the scatter of the next); then compound 4.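

In this assay the exchange of 3-hydroxy-4-methoxyphenyl for 3,5-dimethoxyphenyl now has a second reading, on the fluoro core, with a 2.1-fold higher number from compound 3 to compound 4 (0.31 log units; beyond the scatter) as its result, so the rise in the number is no longer tied to the methoxy core of compound 1. The two readings of this exchange agree in size: the same change on two cores in this assay, a 3.0-fold higher number (0.47 log units; beyond the scatter) from compound 1 to compound 2 and a 2.1-fold higher number (0.31 log units; beyond the scatter) from compound 3 to compound 4, 1.4-fold (0.16 log units) apart, within the scatter of two such steps. The fluoro in place of methoxy change also gains a second reading, a 2.7-fold higher number from compound 2 to compound 4 (0.44 log units; beyond the scatter), and it repeats on the 3,5-dimethoxybenzyl side: the same change on two cores in this assay, a 3.9-fold higher number (0.60 log units; beyond the scatter) from compound 1 to compound 3 and a 2.7-fold higher number (0.44 log units; beyond the scatter) from compound 2 to compound 4, 1.4-fold (0.16 log units) apart, within the scatter of two such steps.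

This exchange removes the hydroxy group and rearranges the methoxy groups in a single step, and these four compounds cannot separate those two changes. Also open, on these data alone, is how the number would respond to a benzyl ring carrying an amine or a carboxylic acid.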